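Fluoro to chloro on the core of compound 3

The source may report more compounds than this note shows. Statements on the series, on what has been measured and on what is new or still open speak of the compounds shown alone.

Measured in a functional assay on V79 cells (Cricetulus griseus) for cytotoxicity, read by colony formation; a lower number here means a stronger inhibitor, a higher number a weaker inhibitor:
compound 1 `NCC1CCN(c2c(F)cc3c(=O)c(C(=O)O)cn(C4CC4)c3c2Cl)C1`: 8 ug/mL
compound 2 `CC1CN(c2c(F)cc3c(=O)c(C(=O)O)cn(C4CC4)c3c2Cl)CC(C)N1`: 140 ug/mL
compound 3 `NC1CCN(c2c(F)cc3c(=O)c(C(=O)O)cn(C4CC4)c3c2F)CC1`: 23 ug/mL

Compound 3 stands in the middle of this small set, with a number higher than that of compound 1 and lower than that of compound 2. Compound 4 `NC1CCN(c2c(F)cc3c(=O)c(C(=O)O)cn(C4CC4)c3c2Cl)CC1`, not yet measured, keeps the 4-aminopiperidin-1-yl group of compound 3 and differs in one place: chloro in place of fluoro on an aromatic carbon.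

Going by the values given here, no measured step isolates this exchange. Among the compounds with values here, the only step available, an 18-fold higher number from compound 1 to compound 2 (1.24 log units; beyond the scatter), replaces 3-(aminomethyl)pyrrolidin-1-yl with 3,5-dimethylpiperazin-1-yl while chloro stays in place. It shows that a change of that group can move the number in this assay a long way, but it says nothing direct about chloro against fluoro. With no measured evidence for a large shift, no step beyond the scatter is expected, with only a slight lean towards a lower number. The expected step is a 1.3-fold lower number from compound 3 to compound 4 (0.11 log units; within the scatter). For compound 4 the estimated value is 18 ug/mL, with an expected range from 7 ug/mL to 45 ug/mL.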

Compound 4, half-maximal inhibitory concentration: 18 ug/mL
For compound 4 middle estimate and measured number coincide at the digits printed; measured number inside the range.
By their numbers in this assay, from the lowest: compound 1; then compounds 4 and 3 (each within the scatter of the next); then compound 2.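

In this assay the exchange of fluoro for chloro, ortho to a 4-aminopiperidin-1-yl group, gives a 1.3-fold lower number from compound 3 to compound 4 (0.11 log units; within the scatter) and so leaves the number within the scatter with this group in place. With chloro kept on the core, changing the other group does shift the number beyond the scatter: 4-aminopiperidin-1-yl in place of 3,5-dimethylpiperazin-1-yl gives a 7.8-fold lower number from compound 2 to compound 4 (0.89 log units; beyond the scatter) while 4-aminopiperidin-1-yl in place of 3-(aminomethyl)pyrrolidin-1-yl gives a 2.3-fold higher number from compound 1 to compound 4 (0.35 log units; beyond the scatter) as the reverse trend. No measurement at hand offers a reason for any of these steps.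

Going by these compounds alone, the exchange of fluoro for chloro is seen only with 4-aminopiperidin-1-yl, so its size with 3-(aminomethyl)pyrrolidin-1-yl or 3,5-dimethylpiperazin-1-yl stays open. From the compounds shown here alone, what a bromo, methyl or methoxy group would do on this aromatic carbon also stays open.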